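A few compounds are considered here, and "the series" means these few. Any claim that something is new, unique, unknown or untested is made for them only; others in the source may bear on it.

Compound 1 `CCOC(=O)c1cnc(C)nc1NN1C(=O)C=C(C)C1=O` gives 16000 nM in a functional assay on Jurkat cells for inhibition of nuclear factor NF-kappa-B complex (Homo sapiens); on this read-out lower numbers stand for stronger inhibition and higher numbers for weaker inhibition. Among the compounds with values here, compound 2 `CCOC(=O)c1cnc(-c2ccc(C(F)(F)F)cc2)nc1NN1C(=O)C=C(C)C1=O` gives 400 nM, the lowest of the two numbers so far, after a 40-fold lower number from compound 1 to compound 2 (1.60 log units; beyond the scatter). Compound 3 `CCOC(=O)c1cnc(-c2ccsc2)nc1NN1C(=O)C=C(C)C1=O` carries thiophen-3-yl in place of 4-(trifluoromethyl)phenyl on an aromatic carbon. Within the data shown here, only that one step bears on this change: it showed that an aromatic ring in this position, replacing methyl, brought a large drop. Since compound 3 keeps an aromatic ring there, its number is expected nearer to compound 2 than to compound 1, with a modest rise expected, a 2.5-fold higher number from compound 2 to compound 3 (0.40 log units; beyond the scatter). Compound 3 is therefore estimated at 1000 nM, in the range 250 nM to 5000 nM.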

Compound 3, half-maximal inhibitory concentration: 100 nM
Compound 3: the middle estimate sits 10-fold (1.00 log units) above what was measured; measured number outside the range, below it.
By their numbers in this assay, from the lowest: compound 3; then compound 2; then compound 1.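

Swapping 4-(trifluoromethyl)phenyl for thiophen-3-yl, which has fewer heavy atoms, gives a 4.0-fold lower number from compound 2 to compound 3 (0.60 log units; beyond the scatter) and shows that the larger group is not needed for a low number at this position. Thiophen-3-yl in place of methyl gives a 160-fold lower number from compound 1 to compound 3 (2.20 log units; beyond the scatter) overall, so a five-membered aromatic ring with one sulfur atom does better here than both other groups. Nothing available explains this difference.

Still open, going by these compounds, is whether other rings, such as thiophen-2-yl or pyridin-3-yl, would match compound 3 at this position. On these data alone, whether a non-aromatic group, such as cyclohexyl or an amine, can do so is equally open.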